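Ester-to-ether change on the shikonin side chain

The source may hold more compounds than are shown below. What is called first, only, known or untested is meant among the compounds shown, and "the series" means these compounds.

Three esters of the shared core have been measured in a functional assay on HeLa cells (Homo sapiens) for cytotoxicity, read by MTT assay; a lower number here means a stronger inhibitor, a higher number a weaker inhibitor. Compound 1 `CC(C)=CC[C@@H](OC(=O)CC(C)(O)c1ccccc1)C1=CC(=O)c2c(O)ccc(O)c2C1=O` gives 85700 nM, compound 2 `CC(C)=CC[C@@H](OC(=O)C1CCCO1)C1=CC(=O)c2c(O)ccc(O)c2C1=O` gives 17000 nM, and compound 3 `CCCC(CC(=O)O[C@H](CC=C(C)C)C1=CC(=O)c2c(O)ccc(O)c2C1=O)OC(C)=O` gives 51200 nM. Compound 2 holds the lowest number of the three; its nearest neighbour is compound 3, and both steps away from it lie beyond the scatter: a 3.0-fold higher number from compound 2 to compound 3 (0.48 log units; beyond the scatter) and, from the other side, a 5.0-fold lower number from compound 1 to compound 2 (0.70 log units; beyond the scatter).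

Compound 4 `CCC(O)CO[C@H](CC=C(C)C)C1=CC(=O)c2c(O)ccc(O)c2C1=O` is the next member. It differs from compound 2 as follows: 2-hydroxybutyl in place of (oxolan-2-yl)carbonyl on an oxygen on a saturated carbon. The ester carbonyl is gone, and an ether bearing a hydroxyl takes its place.

The measured steps bear only partly on this change. a 5.0-fold lower number from compound 1 to compound 2 (0.70 log units; beyond the scatter) and a 3.0-fold higher number from compound 2 to compound 3 (0.48 log units; beyond the scatter) both vary the group on the carbonyl carbon and show modest shifts, with compound 2 at the low end. For the measured compounds named here, no measured step removes the carbonyl itself, so the effect of that loss is not covered. Given that every departure from the oxolane gave a higher number, compound 4 is expected to read higher than compound 2 by a modest step, a 2.4-fold higher number from compound 2 to compound 4 (0.37 log units; beyond the scatter).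

The estimate for compound 4 in this assay is 40000 nM, with a range of 12000 nM to 130000 nM.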

Compound 4, half-maximal inhibitory concentration: 28700 nM
Compound 4: the middle estimate sits 1.4-fold (0.14 log units) above what was measured; low and high end bracket the measured number.
By their numbers in this assay, from the lowest: compounds 2, 4, 3 and 1 (each within the scatter of the next, the first and the last beyond it).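

In this assay the exchange of (oxolan-2-yl)carbonyl for 2-hydroxybutyl on this oxygen stays within the scatter (a 1.7-fold higher number from compound 2 to compound 4 (0.23 log units; within the scatter)), although the carbonyl and the five-membered ring both leave and a hydrogen-bond donor enters. The earlier steps shown here varied only the group on a retained carbonyl carbon, whereas this pair shows that a reading indistinguishable from that of compound 2 does not depend on the ester carbonyl, so ether and ester are both workable links at this position on the present evidence. No available measurement accounts for this outcome.

The change removes the carbonyl and the ring and adds the hydroxyl in a single step, so the contribution of each remains unresolved, and the similar readings could reflect either little effect from any of them or effects that offset one another. An oxolan-2-ylmethyl ether would keep the ring without the carbonyl, while a plain butyl ether or a 2-aminobutyl ether would test whether the hydroxyl matters on the same chain.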